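The compounds below may be only part of what the source reports. "The series", "measured", "known", "first", "only" and "open" are said of these compounds alone.

The shared core of this small set is seen in compound 1 `Nc1cc(N)c2nc(-c3ccccc3)c(Oc3ccc(Cl)c(Cl)c3)nc2c1`, which in a functional assay on MDA-MB-435 cells (Homo sapiens) for inhibition, read by sulforhodamine B assay, with a stated time of 48 h (on this read-out higher numbers stand for weaker inhibition of growth and lower numbers for stronger inhibition of growth), gives 5010 nM. Within the data shown here, of the three numbers so far, compound 1 stands second highest. Its nearest neighbour is compound 3 `COc1ccc(CNc2nc3cc(N)cc(N)c3nc2-c2ccccc2)cc1OC`, which in this assay gives 1950 nM, a lower number that lies beyond the scatter. Furthest from compound 1 is compound 2 `CCOC(=O)[C@H](CCC(=O)O)NC(=O)c1ccc(Oc2nc3cc(N)cc(N)c3nc2-c2ccccc2)cc1`, which in this assay gives 30200 nM, a higher number, again beyond the scatter. Among the measured compounds shown here, no single-site step between measured compounds is available here, so the step to compound 4 rests on the structural change alone.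

Compound 4 `COc1ccc(Sc2nc3cc(N)cc(N)c3nc2-c2ccccc2)cc1` differs from compound 1 in one place: (4-methoxyphenyl)sulfanyl in place of 3,4-dichlorophenoxy on an aromatic carbon. The group that enters is of the same size as the one that leaves, sitting on the same aromatic carbon next to the ring nitrogen.

Compound 4 is expected to give 3000 nM in this assay, with a range from 800 nM to 12000 nM. The step of a 1.7-fold lower number from compound 1 to compound 4 (0.22 log units; within the scatter) that this estimate means is expected to be a modest one toward stronger inhibition, likely within the scatter.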

Compound 4, concentration for 50% growth inhibition: < 100000 nM
Compound 4 ended at the assay's limit (the forecaster's own chance of this, stated with the estimate: 5%); the middle value does not contradict the limit.
By their numbers in this assay, from the lowest: compound 3; then compound 1; then compound 2.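

In this assay compound 4 gives < 100000 nM, which is a limit and not a number, so no step from compound 1 to compound 4 can be read: the limit of < 100000 nM in this assay, at which 1 of the 4 values shown sits.

The compounds shown leave open whether (4-methoxyphenyl)sulfanyl in place of 3,4-dichlorophenoxy changes growth inhibition at all, and in which direction.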